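Ring size at the amine position of the shared core

This account rests on a few compounds, and the source may have more. Where it says the series, first, only, none or still open, it means among the compounds named here.

The series shares one core, with the varying group on an aromatic carbon of the fused ring system. In a functional assay on cells for antagonist activity at prostaglandin E2 receptor EP1 subtype (Rattus norvegicus), read by fluorescence and calcium flux, with a stated time of 60 s (on this read-out lower numbers stand for stronger inhibition and higher numbers for weaker inhibition), compound 1 `O=C(O)c1cccc(Cc2c(-c3ccsc3)nn3cc(Cl)ccc23)n1` gives 110 nM, compound 2 `CC(C)(C)c1nn2cc(Cl)ccc2c1Cc1cccc(C(=O)O)n1` gives 48 nM and compound 3 `O=C(O)c1cccc(Cc2c(N3CCCC3)nn3cc(Cl)ccc23)n1` gives 1800 nM. Compound 3 stands at the highest of the three numbers: the step of a 16-fold higher number from compound 1 to compound 3 (1.21 log units; beyond the scatter) and the step of a 38-fold higher number from compound 2 to compound 3 (1.57 log units; beyond the scatter) are both large and beyond the scatter, while a 2.3-fold lower number from compound 1 to compound 2 (0.36 log units; beyond the scatter) is modest.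

Compound 4 `O=C(O)c1cccc(Cc2c(N3CCCCCC3)nn3cc(Cl)ccc23)n1` differs from compound 3 in one place: azepan-1-yl in place of pyrrolidin-1-yl on an aromatic carbon. Going by the values given here, no measured step compares two saturated amine rings of different size; the two large steps above only show that pyrrolidin-1-yl gives a much higher number than thiophen-3-yl or tert-butyl, and they do not tell whether a wider saturated ring moves the number back. The expectation for this assay is therefore a step of uncertain direction, likely no larger than modest, expressed as a 1.5-fold lower number from compound 3 to compound 4 (0.18 log units; within the scatter). Compound 4 is estimated at 1200 nM in this assay, with a range from 300 nM to 5000 nM.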

Compound 4, half-maximal inhibitory concentration: 1400 nM
Compound 4: middle estimate off by 1.2-fold (0.07 log units), on the low side; the range from low to high includes it.
By their numbers in this assay, from the lowest: compound 2; then compound 1; then compounds 4 and 3 (each within the scatter of the next).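

In this assay, the two saturated amine rings are not told apart at this position: a 1.3-fold lower number from compound 3 to compound 4 (0.11 log units; within the scatter), so going from the five-membered to the seven-membered non-aromatic ring gives no readable shift. The gap to the other groups is also not peculiar to pyrrolidin-1-yl, since azepan-1-yl shows it too, with a 29-fold higher number from compound 2 to compound 4 (1.46 log units; beyond the scatter) and a 13-fold higher number from compound 1 to compound 4 (1.10 log units; beyond the scatter), both large and beyond the scatter; among the four compounds shown, both saturated amine rings sit well apart from tert-butyl and thiophen-3-yl, and no compound goes against this. Nothing at hand gives a reason for that gap.

Open still is whether piperidin-1-yl or morpholin-4-yl, the latter with an oxygen added to the ring, falls in line with the two saturated amine rings shown. An open-chain amine such as diethylamino and a ring without nitrogen such as cyclopentyl, placed on the same aromatic carbon, would show whether the higher numbers go with the ring nitrogen attached there or with the saturated ring itself.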